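This account rests on a few compounds, and the source may have more. Where it says the series, first, only, none or still open, it means among the compounds named here.

Compound 1, `O=C([C@H]1C[C@H]1F)N1CC2CC(C1)N2`: 27 nM
Compound 2, `O=C([C@@H]1C[C@@H]1F)N1CC2CC(C1)N2`: 55 nM

The two measured compounds are built from exactly the same atoms and bonds; they differ only in how two stereocentres at saturated ring carbons are drawn, so compound 2 is the mirror image of compound 1. For the measured compounds named here, in an assay on CHO cells for displacement of a labelled ligand from Neuronal acetylcholine receptor; alpha3/alpha6/beta2/beta3 (Homo sapiens), read by scintillation counting (a lower number here means a stronger inhibitor, a higher number a weaker inhibitor), compound 1 gives 27 nM and compound 2 gives 55 nM, which is the higher of the two numbers so far. Going by the values given here, the single measured step is a 2.0-fold higher number from compound 1 to compound 2 (0.31 log units; beyond the scatter); it shows that swapping both centres at once costs only a little, and the one piece of evidence that bears on it is the fact that one of compounds 1 and 2 is drawn with a defined configuration and the other without, at the place where they differ.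

Compound 3, `O=C([C@H]1C[C@@H]1F)N1CC2CC(C1)N2`, has not yet been measured. Its difference from compound 2 is the two compounds have the same atoms and bonds; at least one stereo element is drawn with a configuration in one of them and without one in the other: 1 of 4 stereo elements differ; a stereocentre at a saturated ring carbon is drawn S in compound 2 and R in compound 3. Only one of the two centres changes, so compound 3 is not a mirror image of either measured compound but a new spatial arrangement. Among the compounds with values here, the only guide is the step from compound 1 to compound 2, which was small, so in this assay a change of roughly that size, in either direction, is expected. Compound 3 is therefore estimated at 40 nM, with a likely range of 12 nM to 150 nM. The step that this estimate means from compound 2 is expected to be a 1.4-fold lower number from compound 2 to compound 3 (0.14 log units; within the scatter).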

Compound 3, inhibition constant: 490 nM
For compound 3 the middle estimate is 12-fold (1.09 log units) below the measured one, outside the stated range (above it).
By their numbers in this assay, from the lowest: compound 1; then compound 2; then compound 3.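

In this assay the configuration turns out to matter far more than the earlier pair suggested: changing one stereocentre at a saturated ring carbon gives an 8.9-fold higher number from compound 2 to compound 3 (0.95 log units; beyond the scatter), and changing the other gives an 18-fold higher number from compound 1 to compound 3 (1.26 log units; beyond the scatter). Changing both centres together cost much less, so among these three compounds the number follows how the two centres stand relative to each other more closely than the overall handedness of the molecule, an arrangement that compound 1 and compound 2 share and compound 3 does not. Since the atoms and bonds are identical, the only thing that can be pointed to for this loss is the configuration itself: the fact that one of compounds 2 and 3 is drawn with a defined configuration and the other without, at the place where they differ.

The mirror image of compound 3 would complete the set of four stereoisomers and would show whether its relative arrangement is poor in both forms or only in one. On these data alone, it also remains open whether the same preference would hold with a chlorine or a methyl group in place of the fluorine.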